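Thiophen-2-yl replaced by phenyl on the shared core

A few compounds are considered here, and "the series" means these few. Any claim that something is new, unique, unknown or untested is made for them only; others in the source may bear on it.

Three compounds share one core. Compound 1 `Oc1cccc(-c2cc(-c3ccncc3)nc(-c3cccc(Cl)c3)c2)c1` stands as "not determined" (no result reported) in a functional assay on T47D cells (Homo sapiens) for cytotoxicity, read by CCK-8 assay and cell counting, with a stated time of 2 days (on this read-out lower numbers stand for stronger inhibition and higher numbers for weaker inhibition), with no number reported. For the measured compounds named here, compound 2 `Oc1cccc(-c2cc(-c3cccc(Cl)c3)nc(-c3cccs3)c2)c1` gives 3410 nM in this assay and is the only entry with a number, the further entry carrying none, so its standing relative to another measured compound cannot be stated. Compound 3 `Oc1cccc(-c2cc(-c3ccccc3)nc(-c3cccc(Cl)c3)c2)c1` has not yet been measured in this assay. It differs from compound 2 in one place: phenyl in place of thiophen-2-yl on an aromatic carbon. Going by the values given here, no step between measured compounds covers this change, so the size of the step for compound 3 rests on expectation alone. Phenyl in place of thiophen-2-yl on an aromatic carbon is a modest alteration of one aromatic ring for another, and no shift beyond the usual scatter is expected in this assay in either direction. For compound 3 the step expected is a 1.1-fold lower number from compound 2 to compound 3 (0.06 log units; within the scatter), essentially flat. Compound 3 is estimated at 3000 nM in this assay, with a range from 1000 nM to 9000 nM. A number rather than a limit is anticipated.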

Compound 3, half-maximal inhibitory concentration: 3700 nM
Compound 3: middle estimate off by 1.2-fold (0.09 log units), on the low side, and the stated range covers the measured number.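

In this assay, for the compounds shown here, phenyl in place of thiophen-2-yl on an aromatic carbon, next to the ring nitrogen, gives a 1.1-fold higher number from compound 2 to compound 3 (0.04 log units; within the scatter), the first step that can be read at this position. Compound 2 and compound 3 therefore cannot be told apart here, so this position accepts a six-membered aromatic ring of carbon only as well as a five-membered aromatic ring with one hetero atom, and neither the sulfur nor the hydrogen-bond acceptor counted for thiophen-2-yl is needed to hold the read-out at this level. No measurement bears on why the two rings read alike.

The steps from compound 1 to compound 2 and to compound 3 cannot be read, so the shown compounds say nothing on a ring nitrogen at this position. Going by these compounds, it also stays open whether this tolerance extends beyond unsubstituted aromatic rings, for example to a phenyl carrying an amine or a carboxylic acid, or to a non-aromatic group such as a morpholine ring or a longer alkyl chain.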